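The source may report more compounds than this note shows. Statements on the series, on what has been measured and on what is new or still open speak of the compounds shown alone.

Working notes on the series. In a functional assay on A549 cells (Homo sapiens) for inhibition, read by MTT assay, with a stated time of 72 h (a lower number here means a stronger inhibitor, a higher number a weaker inhibitor), compound 1 (`C=C(c1cc(Cl)cc(Cl)c1OCc1ccccc1)C1COC2(CCCCC2)OO1`) gives only a limit, > 100000 nM. Compound 2 (`C=C(c1ccc(F)c(F)c1)C1COC(C)(C)OO1`) also gives only a limit, > 100000 nM. Going by the values given here, compound 2 therefore has no number of its own, and no order can be read between the two compounds; the position so far is the limit of > 100000 nM in this assay, at which 2 of the 2 values shown sit.

Compound 3 (`C=C(c1ccc(OC)c(F)c1)C1COC(C)(C)OO1`) has methoxy in place of fluoro on an aromatic carbon of the six-membered aromatic ring of compound 2, at the place ortho to a fluoro group and para to a large group: methoxy in place of fluoro on an aromatic carbon. Among the compounds with values here, no step between measured compounds is available to size this change. The expectation in this assay is no step beyond the scatter, and it rests on compound 2 with its limit of > 100000 nM. The estimated step is a number no higher from compound 2 to compound 3 (the limit leaves the size open). A further report as a limit is the likeliest outcome. For compound 3 the expected value is 100000 nM, with an estimated range of 30000 nM to 200000 nM.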

Compound 3, half-maximal inhibitory concentration: 100000 nM
Beside the measured number, compound 3's estimate shows no gap at the digits printed; the measured number falls inside the stated range.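

In this assay, going by these compounds alone, compound 3 gives 100000 nM, the only value shown that is a number and not a limit. Compound 2 remains a limit at > 100000 nM. The change of fluoro to methoxy, at the place ortho to a fluoro group and para to a large group, therefore reads only as a number no higher from compound 2 to compound 3 (the limit leaves the size open), and the series stays at the edge of what this read-out reports: the limit of > 100000 nM in this assay, at which 2 of the 3 values shown sit.

Within the data shown here, open is whether any other group at this place, such as an amine or a carboxylic acid, would give a number clearly lower than the one for compound 3. Also open, on these data alone, is whether methoxy would give a number on the core of compound 1, which differs from compound 2 in more than one place.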